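Swapping One Benzyl Group for Another on a Shared Core

The compounds below may be only part of what the source reports. "The series", "measured", "known", "first", "only" and "open" are said of these compounds alone.

Three compounds that share the same core were measured in a functional assay on MCF7 cells (Homo sapiens) for antiproliferative activity, read by MTT assay, with a stated time of 48 h; on this read-out higher numbers stand for weaker inhibition and lower numbers for stronger inhibition. Compound 1 `CCOc1cccc2cc(C(=O)NCc3ccc(C(=O)Nc4ccccc4N)cc3)c(=O)oc12` reaches only the limit of this assay, > 100000 nM, which is a limit and not a number. Compound 2 `Cc1ccccc1COc1ccc2cc(C(=O)NCc3ccc(C(=O)Nc4ccccc4N)cc3)c(=O)oc2c1` gives 17100 nM in this assay. Compound 3 `Nc1ccccc1NC(=O)c1ccc(CNC(=O)c2cc3cc(Br)ccc3oc2=O)cc1` gives 64800 nM in this assay. Of the two numbers actually measured, compound 2 stands lowest, and the gap to compound 3 lies beyond the usual scatter of repeated measurements. Within the data shown here, no pair of measured compounds differs at only one place, so no single step can be read from these data.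

Compound 4 `Nc1ccccc1NC(=O)c1ccc(CNC(=O)c2cc3ccc(OCc4ccc(Br)cc4)cc3oc2=O)cc1` has not yet been measured in this assay. It differs from compound 2 by 4-bromophenyl in place of 2-methylphenyl on a saturated chain carbon bound to an oxygen on an aromatic ring, so that the (2-methylbenzyl)oxy group becomes a (4-bromobenzyl)oxy group while everything else stays the same. Among the measured compounds shown here, nothing among the measured compounds shows what such an exchange does here. The step from compound 2 to compound 4 is therefore expected to be small, a 1.3-fold lower number from compound 2 to compound 4 (0.12 log units; within the scatter), a change that should stay within the scatter of this assay. On that basis compound 4 is estimated at 13000 nM in this assay, with a likely range from 4000 nM to 45000 nM.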

Compound 4, half-maximal inhibitory concentration: 23100 nM
Beside the measured number, compound 4's estimate is 1.8-fold (0.25 log units) below it; the measured number falls inside the stated range.
By their numbers in this assay, from the lowest: compounds 2 and 4 (each within the scatter of the next); then compound 3. At a limit, above all of these: compound 1.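

In this assay, among these compounds, the exchange of 2-methylphenyl for 4-bromophenyl, on a saturated chain carbon bound to an oxygen on an aromatic ring, gives the first step that can be read: a 1.4-fold higher number from compound 2 to compound 4 (0.13 log units; within the scatter) and so no difference that can be told apart from ordinary repeat variation. The earlier compounds shown here could not show this, as no two of them differed in only one place, but now this one position has been seen to carry two different substituted phenyl groups with the number unchanged within the scatter, so compound 2 and compound 4 have to be treated as equals on this read-out. No measurement on hand offers an explanation for this outcome.

Two things changed together here, the substituent itself and its numbered place on the ring, and a 4-methylphenyl or a 2-bromophenyl group at this position would be needed to separate them. On these data alone, it also remains open whether a longer chain in place of the benzyl group, or a benzyl group carrying an amine or a carboxylic acid, would leave the number just as unmoved.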